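Urea substituent changes on a quinoline-oxadiazole piperidine series

The source may report more compounds than this note shows. Statements on the series, on what has been measured and on what is new or still open speak of the compounds shown alone.

Measured compounds:
compound 1 `COc1ccccc1NC(=O)N1CCC(c2nc(-c3ccc4ccccc4n3)no2)CC1` — 410 nM
compound 2 `O=C(NC1CC[S+]([O-])CC1)N1CCC(c2nc(-c3ccc4ccccc4n3)no2)CC1` — 850 nM
compound 3 `Cc1noc(C)c1NC(=O)N1CCC(c2nc(-c3ccc4ccccc4n3)no2)CC1` — 3000 nM

In a functional assay on Shh Light II cells (Mus musculus) for inhibition, read by a luciferase reporter (a lower number here means a stronger inhibitor, a higher number a weaker inhibitor), compound 3 gives 3000 nM, the highest number of the three; compound 2 sits at 850 nM and compound 1 at 410 nM.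

Compound 4 `Cc1ccccc1NC(=O)N1CCC(c2nc(-c3ccc4ccccc4n3)no2)CC1` is unmeasured. It differs from compound 3 by 2-methylphenyl in place of 3,5-dimethyl-1,2-oxazol-4-yl on an amide-type nitrogen. The closest measured step is a 7.3-fold higher number from compound 1 to compound 3 (0.86 log units; beyond the scatter), where the same kind of five-membered aromatic ring replaced a six-membered aromatic ring of carbon only. Reversing that change back toward a carbon-only ring, the expected step is a 6.7-fold lower number from compound 3 to compound 4 (0.82 log units; beyond the scatter), landing compound 4 close to compound 1. The estimate for compound 4 in this assay is 450 nM, within 150 nM to 1300 nM.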

Compound 4, half-maximal inhibitory concentration: 440 nM
Estimate against measurement, compound 4: 1.0-fold (0.01 log units) above, within the range that was stated.
By their numbers in this assay, from the lowest: compounds 1, 4 and 2 (each within the scatter of the next, the first and the last beyond it); then compound 3.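

Replacing 3,5-dimethyl-1,2-oxazol-4-yl with 2-methylphenyl on the amide-type nitrogen recovers the potency lost with that five-membered ring (a 6.8-fold lower number from compound 3 to compound 4 (0.83 log units; beyond the scatter)). Methyl and methoxy on the aromatic carbon are not told apart (a 1.1-fold higher number from compound 1 to compound 4 (0.03 log units; within the scatter)), and 2-methylphenyl is not separated from the non-aromatic sulfur-containing ring (a 1.9-fold lower number from compound 2 to compound 4 (0.29 log units; within the scatter)). No supporting measurement accounts for the weaker 3,5-dimethyl-1,2-oxazol-4-yl result.

Still open, as far as these compounds go, is whether unsubstituted phenyl, a chlorophenyl or a pyridyl on the amide-type nitrogen would differ from 2-methylphenyl.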